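The source may hold more compounds than are shown below. What is called first, only, known or untested is meant among the compounds shown, and "the series" means these compounds.

Three related compounds have numbers in a functional assay on HCT-116 cells (Homo sapiens) for antiproliferative activity; a lower number here means a stronger inhibitor, a higher number a weaker inhibitor. Compound 2 `CC[C@H](C)[C@H]1C(=O)N[C@H](Cc2ccc(O)c(Br)c2)C(=O)N[C@@H](C(C)(C)O)C(=O)O[C@H](c2ccccc2)[C@H](C)/C=C/C=C(\C)[C@H](OC)C[C@@H]2O[C@@]2(C)C(=O)N1C` gives 1.59 nM, which puts it at the potent end of this small set. Compound 3 `CC[C@H](C)[C@H]1C(=O)N[C@H](Cc2cc(Cl)c(O)c(Cl)c2)C(=O)N[C@@H](C(C)(C)O)C(=O)O[C@H](c2ccccc2)[C@H](C)/C=C/C=C(\C)[C@H](OC)C/C=C(\C)C(=O)N1C` gives 1.6 nM. These two values lie within the usual scatter and cannot be told apart. Compound 1 `CC[C@H](C)[C@H]1C(=O)N[C@H](Cc2cc(Cl)c(O)c(Cl)c2)C(=O)N[C@@H](C(C)C)C(=O)O[C@H](c2ccccc2)[C@H](C)/C=C/C=C(\C)[C@H](OC)C[C@@H]2O[C@@]2(C)C(=O)N1C` gives 4.25 nM, a higher number than that of compound 2 by a gap beyond the scatter.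

The compound still to be measured is compound 4 `CC[C@H](C)[C@H]1C(=O)N[C@H](Cc2ccc(O)c(Br)c2)C(=O)N[C@@H](C(C)C)C(=O)O[C@H](c2ccccc2)[C@H](C)/C=C/C=C(\C)[C@H](OC)C[C@@H]2O[C@@]2(C)C(=O)N1C`, which matches compound 2 except at one place: hydrogen in place of hydroxy on a saturated chain carbon bound to two saturated chain carbons and a saturated ring carbon. Hydrogen stands in place of hydroxy on a saturated chain carbon bound to two saturated chain carbons and a saturated ring carbon, so 1-hydroxy-1-methylethyl becomes isopropyl. Among the measured compounds shown here, no measured pair isolates this change. For the measured compounds named here, the only hint comes from compound 1, which also carries isopropyl and gives 4.25 nM, but it differs from compound 2 elsewhere too, so it is a loose guide. In this assay a small rise in the number is therefore expected, probably not clearly beyond the scatter. The expected step is a 1.8-fold higher number from compound 2 to compound 4 (0.25 log units; within the scatter), towards a weaker inhibitor. For compound 4 the estimated value is 2.8 nM, with a range of 1.2 nM to 7 nM.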

Compound 4, half-maximal inhibitory concentration: 3.93 nM
For compound 4 the middle estimate is 1.4-fold (0.15 log units) below the measured one; the measured number falls inside the stated range.
By their numbers in this assay, from the lowest: compounds 2 and 3 (each within the scatter of the next); then compounds 4 and 1 (each within the scatter of the next).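

In this assay, the change from 1-hydroxy-1-methylethyl to isopropyl can now be read on its own, with the rest of the molecule held constant: hydrogen in place of hydroxy gives a 2.5-fold higher number from compound 2 to compound 4 (0.39 log units; beyond the scatter), a modest step towards a weaker inhibitor, so this saturated chain carbon does respond to losing its hydroxy. With isopropyl kept in place, 3-bromo-4-hydroxyphenyl in place of 3,5-dichloro-4-hydroxyphenyl gives a 1.1-fold lower number from compound 1 to compound 4 (0.03 log units; within the scatter), so these two aryl groups cannot be told apart on this background in this assay. Nothing in the available data accounts for the step at the chain carbon.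

The compounds shown leave open whether hydrogen in place of hydroxy gives a similar step when 3,5-dichloro-4-hydroxyphenyl replaces 3-bromo-4-hydroxyphenyl, since compound 3 differs from compound 1 in more than one place and cannot settle this. They also leave open how a methoxy or an amine on the same carbon would compare with the hydroxy of compound 2 and the hydrogen of compound 4.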